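The source may hold more compounds than are shown below. What is called first, only, known or untested is meant among the compounds shown, and "the series" means these compounds.

Of the compounds shown here, three sharing one core have been read in a functional assay on MCF7 cells (Homo sapiens) for inhibition, read by MTT assay, with a stated time of 24 h; a higher number here means a weaker inhibitor of growth, a lower number a stronger inhibitor of growth. Compound 1 `Cn1cc(-c2nc3ccccc3n2C(=O)c2ccccc2)c2cc(Br)ccc21`, which carries a phenyl on the carbonyl carbon, gives 50300 nM. Compound 2 `COc1ccc(C(=O)n2c(-c3cn(C)c4ccc(Br)cc34)nc3ccccc32)cc1` gives 19200 nM, and compound 3 `COc1ccc(C(=O)n2c(-c3cn(C)c4ccc(Br)cc34)nc3ccccc32)cc1OC` gives 11300 nM. Compound 3 has the lowest number of the three, but only one of its two gaps counts: a 4.5-fold lower number from compound 1 to compound 3 (0.65 log units; beyond the scatter) goes beyond the scatter, whereas a 1.7-fold lower number from compound 2 to compound 3 (0.23 log units; within the scatter) does not.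

The next compound, compound 4 `Cn1cc(-c2nc3ccccc3n2C(=O)c2ccccc2Br)c2cc(Br)ccc21`, keeps the shared core and alters one group: 2-bromophenyl in place of 3,4-dimethoxyphenyl on a carbonyl carbon. This puts 2-bromophenyl in place of 3,4-dimethoxyphenyl on a carbonyl carbon. Among the compounds with values here, no measured step places bromine on this phenyl, so the evidence is indirect. The methoxy steps, a 2.6-fold lower number from compound 1 to compound 2 (0.42 log units; beyond the scatter) and a 4.5-fold lower number from compound 1 to compound 3 (0.65 log units; beyond the scatter), are both modest, and they set the size of what may be lost when the methoxy groups leave. Compound 4 is therefore expected to give back part of that ground, while the bromine's own contribution remains unmeasured. The expected change is a modest one towards a higher number, a 2.1-fold higher number from compound 3 to compound 4 (0.33 log units; beyond the scatter). For compound 4 the estimated value is 24000 nM, with an expected range from 8000 nM to 60000 nM.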

Compound 4, concentration for 50% growth inhibition: 73600 nM
Estimate against measurement, compound 4: 3.1-fold (0.49 log units) below; the measured number lies above the stated range.
By their numbers in this assay, from the lowest: compounds 3 and 2 (each within the scatter of the next); then compounds 1 and 4 (each within the scatter of the next).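

In this assay, bromo in place of hydrogen on the phenyl gives no readable change, with a 1.5-fold higher number from compound 1 to compound 4 (0.17 log units; within the scatter), so at this carbonyl carbon the 2-bromophenyl cannot be told apart from the unsubstituted phenyl. Both methoxy-bearing compounds stand clear of the bromo compound, with a 6.5-fold higher number from compound 3 to compound 4 (0.81 log units; beyond the scatter) and a 3.8-fold higher number from compound 2 to compound 4 (0.58 log units; beyond the scatter), which shows that the ground held by the 3,4-dimethoxyphenyl and the 4-methoxyphenyl is lost when 2-bromophenyl enters and that this bromine wins none of it back. Nothing at hand explains this difference in growth inhibition.

The compounds shown leave open whether the gain seen with methoxy extends to other groups on this phenyl, such as an amine or a carboxylic acid, and whether a phenyl carrying both bromine and methoxy would keep that gain. They also leave open what the bromine on the shared core contributes, since all four compounds carry it and none has a hydrogen or a methyl there instead.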